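This account rests on a few compounds, and the source may have more. Where it says the series, first, only, none or still open, it means among the compounds named here.

Compound 1 `CNCc1cccc(Cc2c([C@H](C)Nc3ncnc(N)c3C#N)cc3scc(C)n3c2=O)c1` bears a hydrogen on the amine nitrogen of its side chain. In a physicochemical assay for solubility (a higher number here means a more soluble compound, a lower number a less soluble compound), compound 1 reaches only the limit of the measurement, > 1000000 nM. Compound 2 `Cc1csc2cc([C@H](C)Nc3ncnc(N)c3C#N)c(Cc3cccc(CN(C)CC(C)C)c3)c(=O)n12` carries an isobutyl group on that same nitrogen, and in this assay compound 2 gives 12000 nM. Among the measured compounds shown here, the single measured step between them is an at least 83-fold lower number from compound 1 to compound 2 (1.92 log units; beyond the scatter). For the measured compounds named here, compound 2 is thus the only compound with an actual number, and that number stands below the limit at which compound 1 sits. Compound 3 `Cc1csc2cc([C@H](C)Nc3ncnc(N)c3C#N)c(Cc3cccc(CN(C)C)c3)c(=O)n12` has not yet been measured. It differs from compound 2 by hydrogen in place of isopropyl on a saturated chain carbon bound to an amine nitrogen. Going by the values given here, the only step that bears on this change is the one from compound 1 to compound 2, which was large; compound 3 removes most of what that step added. The evidence on the upper side is the limit of > 1000000 nM in this assay, at which 1 of the 2 values shown sits, which marks where compound 1 stands. A large rise in this assay is therefore expected for compound 3, a 25-fold higher number from compound 2 to compound 3 (1.40 log units; beyond the scatter). For compound 3 the expected value in this assay is 300000 nM, with a range from 60000 nM to 1000000 nM.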

Compound 3, solubility: 956000 nM
Beside the measured number, compound 3's estimate is 3.2-fold (0.50 log units) below it; the measured number falls inside the stated range.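

The earlier step rested on a limit, but this position now has a step between two actual numbers: in this assay, the change from isobutyl to methyl on the amine nitrogen gives an 80-fold higher number from compound 2 to compound 3 (1.90 log units; beyond the scatter). By contrast, methyl in place of hydrogen on that nitrogen gives an at least 1.0-fold lower number from compound 1 to compound 3 (0.01 log units; that floor lies within the scatter), a floor that cannot separate the two compounds, so among the changes shown only the isobutyl group goes with a large step. The value of compound 1 is a limit, and this restricts what the comparison with it can say: the limit of > 1000000 nM in this assay, at which 1 of the 3 values shown sits.

The compounds shown leave open how the number moves with an unbranched chain of intermediate length on the nitrogen, such as ethyl or propyl, and so whether the fall comes gradually or only with the branched isobutyl chain. Also open, as far as these compounds go, is whether a ring amine such as morpholine in place of the side-chain amine would keep the higher number, and how far compound 1 truly lies beyond its limit.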